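This account rests on a few compounds, and the source may have more. Where it says the series, first, only, none or still open, it means among the compounds named here.

Measured compounds in an assay on membranes from brain for displacement of a labelled ligand from Neuronal acetylcholine receptor; alpha4/beta2 (Rattus norvegicus); on this read-out lower numbers stand for stronger inhibition and higher numbers for weaker inhibition:
- compound 1, `CN1CCC[C@H]1COc1cccnc1`: 0.15 nM
- compound 2, `CN1CCC[C@H]1COc1cccnc1Br`: 451 nM
- compound 3, `CSc1ncccc1OC[C@@H]1CCCN1C`: 559 nM

Compound 1 stands lowest of the three values in this assay. The nearest measured compound is compound 2, reached by a 3000-fold higher number from compound 1 to compound 2 (3.48 log units; beyond the scatter); compound 3 lies furthest, reached by a 3700-fold higher number from compound 1 to compound 3 (3.57 log units; beyond the scatter). Between compound 2 and compound 3 the step is a 1.2-fold higher number from compound 2 to compound 3 (0.09 log units; within the scatter), so the two substituted compounds cannot be told apart.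

Compound 4, `CCCCc1cncc(OC[C@@H]2CCCN2C)c1`, has not yet been measured in this assay. Relative to compound 1 the change is butyl in place of hydrogen on an aromatic carbon. The two measured steps from compound 1, both large and each the addition of a substituent to the core of compound 1, are the only guide available; whether the place described for compound 4 behaves like the places probed in compound 2 and compound 3 is not shown by the data. A loss is therefore expected, but one smaller than those measured, with wide uncertainty. The step expected for compound 4 is a 13-fold higher number from compound 1 to compound 4 (1.12 log units; beyond the scatter). Compound 4 is estimated at 2 nM, with a range from 0.3 nM to 20 nM.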

Compound 4, inhibition constant: 0.16 nM
Estimate against measurement, compound 4: 13-fold (1.10 log units) above; measured number outside the range, below it.
By their numbers in this assay, from the lowest: compounds 1 and 4 (each within the scatter of the next); then compounds 2 and 3 (each within the scatter of the next).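

In this assay, butyl in place of hydrogen gives a 1.1-fold higher number from compound 1 to compound 4 (0.03 log units; within the scatter), so at this aromatic carbon, two atoms from the ring nitrogen and meta to a group of 8 heavy atoms, a chain of 4 carbon atoms is tolerated on the core of compound 1. The large steps of a 3000-fold higher number from compound 1 to compound 2 (3.48 log units; beyond the scatter) and a 3700-fold higher number from compound 1 to compound 3 (3.57 log units; beyond the scatter) come from substituents at a different aromatic carbon, and the new result shows that they do not amount to a penalty for every substituent on this ring. No data on hand explain why the two places differ.

Open, from the compounds shown here alone, is whether bromo or methylsulfanyl at this same place would match butyl, which would separate the effect of the place from that of the group. Also open, going by these compounds, is how far this tolerance extends at this place, for instance to a longer chain such as octyl, to a phenyl ring, or to a chain ending in an amine or a carboxylic acid.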